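Amide and alkyl variants at the ring amine, one step

This account rests on a few compounds, and the source may have more. Where it says the series, first, only, none or still open, it means among the compounds named here.

Compound 1 `CCN1CCc2nc(C#Cc3ccccc3)sc2C1`: in an assay on HEK293 cells for positive allosteric modulation of metabotropic glutamate receptor 5 (Homo sapiens), read by FLIPR, with a stated time of 1 h (on this read-out lower numbers stand for an effect already at smaller amounts and higher numbers for an effect only at larger amounts of compound), compound 1 gives > 10000 nM, a limit of the assay.
Compound 2 `CC(C)CN1CCc2nc(C#Cc3ccccc3)sc2C1`: in this assay compound 2 gives > 10000 nM, a limit of the assay.
Compound 3 `O=C(C1CCC1)N1CCc2nc(C#Cc3ccccc3)sc2C1`: in this assay compound 3 gives > 10000 nM, a limit of the assay.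

Compound 3 stands where every measured compound of the series stands, at the limit of > 10000 nM in this assay, at which 3 of the 3 values shown sit; no number separates it from compound 1 or compound 2. For the measured compounds named here, the measured steps a step that the two limits leave unreadable from compound 1 to compound 2, a step that the two limits leave unreadable from compound 1 to compound 3 and a step that the two limits leave unreadable from compound 2 to compound 3 all sit at the limit of > 10000 nM in this assay, at which 3 of the 3 values shown sit, and are unreadable in size, so the series so far gives no direction at all.

The unmeasured compound 4 `O=C(C1CCCO1)N1CCc2nc(C#Cc3ccccc3)sc2C1` differs from compound 3 by oxolan-2-yl in place of cyclobutyl on a carbonyl carbon. The steps that touch the same position, from compound 1 to compound 3 and from compound 2 to compound 3, bear on this change, but both are unreadable, and nothing measured distinguishes a cyclobutyl from an oxolan-2-yl on that carbonyl carbon. The expectation for compound 4 is therefore no readable step, a step that the limit leaves unreadable from compound 3 to compound 4, with a value most likely again reported only as a limit. The estimate for compound 4 in this assay is 15000 nM, within a range from 3000 nM to 50000 nM.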

Compound 4, half-maximal effective concentration: 790 nM
Estimate against measurement, compound 4: 19-fold (1.28 log units) above, outside the stated range (below it).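

For the compounds shown here, the carbonyl carbon is the first position where a change reads out in this assay: oxolan-2-yl in place of cyclobutyl gives an at least 12-fold lower number from compound 3 to compound 4 (1.10 log units; beyond the scatter), and both compounds keep the carbonyl on the amine nitrogen in a ring, so the carbonyl alone does not produce the step. Against the alkyl variants the picture is the same, with an at least 12-fold lower number from compound 2 to compound 4 (1.10 log units; beyond the scatter) and an at least 12-fold lower number from compound 1 to compound 4 (1.10 log units; beyond the scatter), and each of these three steps is a bound rather than an exact size, as it starts from a limit of the assay. Among the compounds shown, only compound 4 carries a number, so (oxolan-2-yl)carbonyl is the one group here that separates from the rest: the limit of > 10000 nM in this assay, at which 3 of the 4 values shown sit.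

The compounds shown do not tell whether the ring oxygen or the five-membered ring size goes with the step, and a cyclopentyl on the same carbonyl carbon would separate the two. Also open, on these data alone, is how far the step carries to other groups at this place, such as oxolan-3-yl, a six-membered oxane or an open methoxymethyl chain.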